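A trifluoromethyl swap in a flat toxicity series

The compounds below may be only part of what the source reports. "The series", "measured", "known", "first", "only" and "open" are said of these compounds alone.

In a toxicity assay on MT4 cells (Homo sapiens) for cytotoxicity, read by MTT assay, with a stated time of 5 days (on this read-out higher numbers stand for lower toxicity in this test and lower numbers for higher toxicity in this test), compound 1 (`Cc1cc(-c2cncnc2)cc(C)c1Nc1ccnc(Nc2ccc(C#N)cc2)n1`) gives 6800 nM, compound 2 (`Cc1cc(-c2ccnc3ccccc23)cc(C)c1Nc1ccnc(Nc2ccc(C#N)cc2)n1`) gives 3500 nM and compound 3 (`Cc1cc(-c2cc(C)c(Nc3ccnc(Nc4ccc(C#N)cc4)n3)c(C)c2)ccn1`) gives 4900 nM, so compound 3 stands within the scatter of both others. Compound 4 (`Cc1cc(-c2cnc(C(F)(F)F)nc2)cc(C)c1Nc1ccnc(Nc2ccc(C#N)cc2)n1`) carries 2-(trifluoromethyl)pyrimidin-5-yl in place of 2-methylpyridin-4-yl on an aromatic carbon. Three swaps at this same place bear on it: a 1.9-fold lower number from compound 1 to compound 2 (0.29 log units; within the scatter), a 1.4-fold lower number from compound 1 to compound 3 (0.14 log units; within the scatter) and a 1.4-fold higher number from compound 2 to compound 3 (0.15 log units; within the scatter). Within the data shown here, all three stay within the scatter, although no measured compound carries a trifluoromethyl group. In this assay, no step beyond the scatter is therefore expected, only an estimated 1.1-fold lower number from compound 3 to compound 4 (0.04 log units; within the scatter). Compound 4 is estimated at 4500 nM, with an expected range of 2000 nM to 10000 nM.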

Compound 4, half-maximal cytotoxic concentration: 4900 nM
For compound 4 the middle estimate is 1.1-fold (0.04 log units) below the measured one, and the stated range covers the measured number.
By their numbers in this assay, from the lowest: compounds 2, 3, 4 and 1 (each within the scatter of the next).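

In this assay a trifluoromethyl group at this position still gives no step beyond the scatter: the steps read no change at the digits printed from compound 3 to compound 4 (within the scatter) and a 1.4-fold higher number from compound 2 to compound 4 (0.15 log units; within the scatter) and a 1.4-fold lower number from compound 1 to compound 4 (0.14 log units; within the scatter) in turn. The last of these is the plainest test, as trifluoromethyl takes the place of hydrogen and nothing else differs. No measurement at hand offers an explanation for this flat picture.

As far as these compounds go, whether an amine or a carboxylic acid in this place would stay equally flat remains open.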